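A few compounds are considered here, and "the series" means these few. Any claim that something is new, unique, unknown or untested is made for them only; others in the source may bear on it.

Compound 1, `COc1ccc(-c2nc3cc(NC(=O)[C@H](C)Oc4cccc(F)c4F)ccc3o2)cc1`: in an assay on isolated protein for inhibition of GMP reductase 2 (Homo sapiens), read by spectrophotometry (a higher number here means a weaker inhibitor, a lower number a stronger inhibitor), compound 1 gives > 5000 nM, which is a limit of the assay.
Compound 2, `C[C@H](Oc1cccc(Cl)c1Cl)C(=O)Nc1ccc2oc(-c3ccc(OC(F)(F)F)cc3)nc2c1`: compound 2 gives > 5000 nM, also a limit.
Compound 3, `C[C@H](Oc1cccc(F)c1F)C(=O)Nc1ccc2oc(-c3ccncc3)nc2c1`: compound 3 gives > 5000 nM, again a limit.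

Compound 2 therefore has no number of its own; it sits where all three measured compounds sit, at the limit of > 5000 nM in this assay, at which 3 of the 3 values shown sit. Compound 4, `C[C@H](Oc1cccc(Cl)c1Cl)C(=O)Nc1ccc2oc(-c3ccc(CN)cc3)nc2c1`, differs from compound 2 by aminomethyl in place of trifluoromethoxy on an aromatic carbon. Going by the values given here, only one measured step exists, and a step that the two limits leave unreadable from compound 1 to compound 3 is unreadable because both ends are limits; it also concerns a different position and does not touch the aminomethyl change. With nothing readable to build on, compound 4 is expected to stay near the measured limits, with an estimated step of a number no higher from compound 2 to compound 4 (the limit leaves the size open). The estimated value for compound 4 is 5000 nM, within 800 nM to 30000 nM.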

Compound 4, inhibition constant: > 5000 nM
Compound 4: a limit, no number; the forecaster's own chance of this, stated with the estimate: 70%; the middle value sits exactly at the limit.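

Compound 2 and compound 4 both sit at a limit, so the step between them cannot be read: the limit of > 5000 nM in this assay, at which 4 of the 4 values shown sit. The compounds shown leave open which structural change, if any, would give an actual number in this assay.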